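Working notes: cell toxicity ahead of compound 4

The source may report more compounds than this note shows. Statements on the series, on what has been measured and on what is new or still open speak of the compounds shown alone.

Compound 1 `Cc1nc2nc(SCc3ccc(Cl)cc3)nn2c(N2CC[C@@H](C)[C@@H](N(C)c3ncnc4[nH]ccc34)C2)c1C` in a toxicity assay on GES1 cells (Homo sapiens) for inhibition, read by MTT assay, with a stated time of 72 h (a lower number here means a stronger inhibitor, a higher number a weaker inhibitor), gives 99200 nM.
Compound 2 `Cc1cc(N2CC[C@@H](C)[C@@H](N(C)c3ncnc4[nH]ccc34)C2)n2nc(SCc3ccc(F)c(Cl)c3)nc2n1` in this assay gives only a limit, > 100000 nM.
Compound 3 `CCc1cc(N2CC[C@@H](C)[C@@H](N(C)c3ncnc4[nH]ccc34)C2)n2ncnc2n1` in this assay gives only a limit, > 100000 nM.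

Compound 2 thus stands at the edge of what this assay can report, not at a number, and (the limit of > 100000 nM in this assay, at which 2 of the 3 values shown sit). Among the compounds with values here, no step between two measured compounds is available. Compound 4 `Cc1cc(N2CC[C@@H](C)[C@@H](N(C)c3ncnc4[nH]ccc34)C2)n2nc(SCCCc3ccccc3)nc2n1` is still to be measured and differs from compound 2 by phenethyl in place of 3-chloro-4-fluorophenyl on a saturated chain carbon bound to a sulfur. With compound 2 at the limit, no step beyond the usual scatter is expected in this assay from compound 2 to compound 4, and a limit again seems the likelier report. For compound 4 the estimate in this assay is 100000 nM, with a range from 50000 nM to 200000 nM. That estimate means an expected step of a number no higher from compound 2 to compound 4 (the limit leaves the size open).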

Compound 4, half-maximal inhibitory concentration: > 100000 nM
Compound 4: no number, only a limit; the forecaster's own chance of this, stated with the estimate: 70%; the middle value lies on the limit itself.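

In this assay compound 4 gives only a limit, > 100000 nM. Compound 2 is a limit too, so no step from it to compound 4 can be read: the limit of > 100000 nM in this assay, at which 3 of the 4 values shown sit.

The compounds shown leave open whether phenethyl in place of 3-chloro-4-fluorophenyl changes the read-out in this assay at all.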